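The compounds below may be only part of what the source reports. "The series", "measured", "known", "first", "only" and "open" are said of these compounds alone.

Going by the values given here, compound 2 `OC[C@H]1O[C@@H](n2cnc3c(CSc4cccc(Cl)c4)ncnc32)[C@H](O)[C@@H]1O` gives 282 nM in an assay on isolated protein for binding affinity to Equilibrative nucleoside transporter 1 (Homo sapiens) (a lower number here means a stronger inhibitor, a higher number a weaker inhibitor), the lowest of the two numbers measured so far; compound 1 `CCCCCNc1ncnc2c1ncn2[C@@H]1O[C@H](CO)[C@@H](O)[C@H]1O` gives 13500 nM in this assay. Among the compounds with values here, the only measured step, a 48-fold lower number from compound 1 to compound 2 (1.68 log units; beyond the scatter), exchanges a whole group on the core and so does not speak directly to the change toward compound 3 `OC[C@H]1O[C@@H](n2cnc3c(CSc4ccc(F)cc4)ncnc32)[C@H](O)[C@@H]1O`, which is 4-fluorophenyl in place of 3-chlorophenyl on a sulfur. Within the data shown here, no measured pair shows a change of this kind, so the expected step of a 1.4-fold higher number from compound 2 to compound 3 (0.15 log units; within the scatter) is small, within or only just beyond the scatter, in either direction. Compound 3 is therefore estimated at 400 nM, expected between 150 nM and 1200 nM.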

Compound 3, half-maximal inhibitory concentration: 158 nM
Compound 3: the middle estimate sits 2.5-fold (0.40 log units) above what was measured; low and high end bracket the measured number.
By their numbers in this assay, from the lowest: compounds 3 and 2 (each within the scatter of the next); then compound 1.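

On the sulfur, 4-fluorophenyl and 3-chlorophenyl are not told apart in this assay (a 1.8-fold lower number from compound 2 to compound 3 (0.25 log units; within the scatter)), so this change of halogen and its ring position has no readable effect here. The large gap to the pentylamino compound also holds with the new group (an 85-fold lower number from compound 1 to compound 3 (1.93 log units; beyond the scatter)), so it is seen with both of these aryl groups. Nothing measured gives a cause for either step. Still open, on these data alone, is whether an aromatic ring on the sulfur is needed at all, which a cyclohexyl group or a butyl chain there would address.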